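From 4-fluorophenyl to 3-ethylphenyl on the amide

A few compounds are considered here, and "the series" means these few. Any claim that something is new, unique, unknown or untested is made for them only; others in the source may bear on it.

compound 1 `CCOc1ccc(NC(=O)C2Cc3cc(OC)c(OC)cc3C2=O)cc1` gives 2.42
compound 2 `COc1cc2c(cc1OC)C(=O)C(C(=O)Nc1ccc(F)cc1)C2` gives 2.36
compound 3 `CCc1cccc(NC(=O)C2Cc3cc(OC)c(OC)cc3C2=O)c1` is not yet measured

In a physicochemical assay for lipophilicity, read by mass spectrometry (a higher number here means a more lipophilic compound, a lower number a more polar compound), the two measured compounds lie within the scatter of each other, and compound 2 stands at 2.36 with no clear order between them. The change to compound 3 is 3-ethylphenyl in place of 4-fluorophenyl on an amide-type nitrogen. Among the compounds with values here, the only measured step that bears on it is fluoro in place of ethoxy on an aromatic carbon (a number 0.06 log units lower from compound 1 to compound 2 (within the scatter)), and it stayed within the scatter. Within the data shown here, no measured compound carries an ethyl group, so this step is a weak guide, and the expectation rests mainly on the structural change itself. The expected step is upward and beyond the scatter (a number 0.54 log units higher from compound 2 to compound 3 (beyond the scatter)). Compound 3 is estimated at 2.9 with an expected range from 2.5 to 3.3 in this assay once measured.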

Compound 3, partition coefficient: 3.11
Beside the measured number, compound 3's estimate is 0.21 log units below it, within the range that was stated.
By their numbers in this assay, from the lowest: compounds 2 and 1 (each within the scatter of the next); then compound 3.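

In this assay, 3-ethylphenyl in place of 4-fluorophenyl on an amide-type nitrogen gives a number 0.75 log units higher from compound 2 to compound 3 (beyond the scatter). Within the data shown here, the only earlier step at this part of the molecule, ethoxy to fluoro on the aromatic ring, stayed within the scatter, so this is the first sign that a change on this aryl group can move the number clearly. Nothing available explains the size or direction of the step.

The compounds shown do not separate the effect of the ethyl group from that of where it sits on the ring, since compound 2 and compound 3 differ in both. They also leave open how the number would respond to a longer chain such as propyl, or to a carboxylic acid, on this phenyl ring.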